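From isopropyl to tert-butyl on compound 2

This account rests on a few compounds, and the source may have more. Where it says the series, first, only, none or still open, it means among the compounds named here.

Within the data shown here, in an ADME assay on the whole organism (Rattus norvegicus) for pharmacokinetics, read by LC-MS (a higher number here means that a larger share of the oral dose reaches the circulation, a lower number that a smaller share of the oral dose reaches the circulation), compound 1 `COc1ccc2c(c1C(=O)O)OB(O)[C@@H](Sc1nncs1)C2` gives 3% and compound 2 `COc1ccc2c(c1C(=O)OCOC(=O)C(C)C)OB(O)[C@@H](Sc1nncs1)C2` gives 100% as the higher of the two numbers so far. Among the measured compounds shown here, the only measured step is a number 97 percentage points higher from compound 1 to compound 2 (beyond the scatter) and comes with ((isopropylcarbonyl)oxy)methyl in place of hydrogen on an oxygen next to a carbonyl group. Compound 3 `COc1ccc2c(c1C(=O)OCOC(=O)C(C)(C)C)OB(O)[C@@H](Sc1nncs1)C2` keeps that oxygen substituted and differs from compound 2 in one place: methyl in place of hydrogen on a saturated chain carbon bound to a carbonyl carbon and two saturated chain carbons turns isopropyl into tert-butyl. For the measured compounds named here, that measured step bears on this change only indirectly, since no measured pair tests a change at this carbon. Compound 2 at 100% leaves no room upward on this read-out, so any real change can only go downward. The expected step is small, and a number 10 percentage points lower from compound 2 to compound 3 (within the scatter) is the estimate taken forward here. Compound 3 is estimated at 90% with an expected range from 60% to 100% on this read-out.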

Compound 3, oral bioavailability: 100%
Estimate against measurement, compound 3: 10 percentage points below, within the range that was stated.
By their numbers in this assay, from the lowest: compound 1; then compounds 2 and 3 (each within the scatter of the next).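

In this assay, the added methyl on a saturated chain carbon bound to a carbonyl carbon and two saturated chain carbons gives no change at the digits printed from compound 2 to compound 3 (within the scatter), so isopropyl and tert-butyl cannot be told apart at this place on this read-out. The large gain over compound 1 is also not confined to the isopropyl version: (((tert-butyl)carbonyl)oxy)methyl shows a number 97 percentage points higher from compound 1 to compound 3 (beyond the scatter), the same size as a number 97 percentage points higher from compound 1 to compound 2 (beyond the scatter) for ((isopropylcarbonyl)oxy)methyl. No supporting data bear on what lies behind these numbers.

On these data alone, with compound 2 and compound 3 both at the top of the read-out, any difference that could exist above that ceiling stays hidden, and how much change this carbon tolerates remains open. A cyclohexyl ring, a longer chain or an amine in place of isopropyl or tert-butyl would test whether the high share of the oral dose reaching the circulation persists, or whether this part of the molecule has a limit on this read-out.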